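The source may report more compounds than this note shows. Statements on the series, on what has been measured and on what is new or still open speak of the compounds shown alone.

For the measured compounds named here, compound 2 `Cc1nc(C)c(CN2CCN(c3cccc4[nH]c(-c5ccc(C(C)(C)C)cc5)nc34)CC2)s1` gives 27 nM in an assay on isolated protein for displacement of a labelled ligand from Gonadotropin-releasing hormone receptor (Homo sapiens) (on this read-out higher numbers stand for weaker inhibition and lower numbers for stronger inhibition), the lowest of the two numbers measured so far, while compound 1 `Cc1ccc(CN2CCN(c3cccc4[nH]c(-c5ccc(C(C)(C)C)cc5)nc34)CC2)o1` gives 705 nM. Compound 3 `Cc1n[nH]c(C)c1CN1CCN(c2cccc3[nH]c(-c4ccc(C(C)(C)C)cc4)nc23)CC1` differs from compound 2 by 3,5-dimethyl-1H-pyrazol-4-yl in place of 2,4-dimethyl-1,3-thiazol-5-yl on a saturated chain carbon bound to an amine nitrogen in a ring. Going by the values given here, the only measured step at this position, a 26-fold lower number from compound 1 to compound 2 (1.42 log units; beyond the scatter), shows that this assay responds strongly to an exchange of the five-membered ring on that carbon; no measured step bears directly on the ring that enters. A step of uncertain direction is therefore estimated for compound 3, as a 2.2-fold higher number from compound 2 to compound 3 (0.35 log units; beyond the scatter), with a somewhat higher number judged more likely. Compound 3 is expected to give 60 nM, in the range 15 nM to 250 nM.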

Compound 3, half-maximal inhibitory concentration: 68 nM
The estimate for compound 3 lay 1.1-fold (0.05 log units) below the measured number, within the range that was stated.
By their numbers in this assay, from the lowest: compound 2; then compound 3; then compound 1.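

The exchange at this position is not all-or-nothing: a second dimethyl-substituted ring, now with a hydrogen-bond donor, gives only a 2.5-fold higher number from compound 2 to compound 3 (0.40 log units; beyond the scatter). The gain over the 5-methylfuran-2-yl group largely remains, with a 10-fold lower number from compound 1 to compound 3 (1.02 log units; beyond the scatter). Nothing available here accounts for the order of these three rings.

The compounds shown do not separate the loss of sulfur from the gain of the ring hydrogen-bond donor. Going by these compounds, how an unsubstituted 1H-pyrazol-4-yl, an amine on the ring or a longer chain carrying the 3,5-dimethyl-1H-pyrazol-4-yl group would read remains open.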